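Shortening the ether side chain on the shared core

A few compounds are considered here, and "the series" means these few. Any claim that something is new, unique, unknown or untested is made for them only; others in the source may bear on it.

Two compounds built on a shared core have been examined in an assay on CHO cells for displacement of a labelled ligand from adenosine receptor A3 (Homo sapiens), read by scintillation counting, with a stated time of 120 min, tested at 1 uM; a lower number here means less inhibition, a higher number more inhibition at the concentration tested (going by the name of the read-out). Compound 1 `N#Cc1c(N)nc(SCC(N)=O)c(C#N)c1-c1ccc(OCC2CC2)cc1` gives 8% in this assay, and compound 2 `CC(C)COc1ccc(-c2c(C#N)c(N)nc(SCC(N)=O)c2C#N)cc1` gives 9%. Compound 2 stands highest of the two numbers, but its nearest neighbour, compound 1, lies within the scatter, so no order between the two can be claimed. Within the data shown here, the only measured step, a number 1 percentage points higher from compound 1 to compound 2 (within the scatter), is itself within the scatter. Compound 3 `CCOc1ccc(-c2c(C#N)c(N)nc(SCC(N)=O)c2C#N)cc1` differs from compound 2 by methyl in place of isopropyl on a saturated chain carbon bound to an oxygen on an aromatic ring. Among the measured compounds shown here, this change sits at the same place as the one measured step, which stayed within the scatter, so the expected step is a number 1 percentage points lower from compound 2 to compound 3 (within the scatter), with no movement beyond the scatter in either direction. Compound 3 is therefore estimated at 8% in this assay, with a range from -2% to 20%.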

Compound 3, a percentage reported as inhibition, at one concentration (the size of the read-out at that concentration, not a potency): 20%
The estimate for compound 3 lay 12 percentage points below the measured number; the measured number falls inside the stated range.
By their numbers in this assay, from the lowest: compounds 1 and 2 (each within the scatter of the next); then compound 3.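

Methyl in place of isopropyl on a saturated chain carbon bound to an oxygen on an aromatic ring gives a number 11 percentage points higher from compound 2 to compound 3 (beyond the scatter) in this assay, and methyl in place of cyclopropyl gives a number 12 percentage points higher from compound 1 to compound 3 (beyond the scatter). Among these compounds, the place is therefore not indifferent to change, which the single step within the scatter between the isopropyl and cyclopropyl groups could not show: the ethoxy compound stands apart from both larger ethers, while those two cannot be ordered. Nothing available explains this difference.

Open remains how a straight propyl chain, a longer chain or a terminal amine or carboxylic acid on the ether would read at this place. With one concentration for each compound, these numbers also give no potency for any of the three.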